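Replacing 2-fluorophenyl with 3-methoxyphenyl on the sulfonyl sulfur

A few compounds are considered here, and "the series" means these few. Any claim that something is new, unique, unknown or untested is made for them only; others in the source may bear on it.

Compound 1 `O=S(=O)(Nc1ccc(-c2nc3ccccc3o2)cc1)c1ccccc1F` was tested in an assay on isolated protein for inhibition of malate dehydrogenase, mitochondrial (Sus scrofa), with stated times of 45 min and 30 min; a higher number here means a weaker inhibitor, a lower number a stronger inhibitor. In this assay compound 1 gives > 63000 nM, which is a limit of the assay and not a number. Compound 2 `O=S(=O)(Nc1ccc2oc(-c3ccccc3)nc2c1)c1ccccc1O` is a close relative. In this assay compound 2 gives > 63000 nM, again only a limit. Compound 1 thus stands at the limit of > 63000 nM in this assay, at which 2 of the 2 values shown sit, with no measured number to set it against. Compound 3 `COc1cccc(S(=O)(=O)Nc2ccc(-c3nc4ccccc4o3)cc2)c1` differs from compound 1 in one place: 3-methoxyphenyl in place of 2-fluorophenyl on a sulfonyl sulfur. Among the measured compounds shown here, no measured pair shows a change of this kind, so in this assay the expected step of a number no higher from compound 1 to compound 3 (the limit leaves the size open) is none beyond the scatter. Compound 3 is expected to give 63000 nM, within 20000 nM to 200000 nM, most likely again as a limit.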

Compound 3, half-maximal inhibitory concentration: > 63000 nM
Compound 3: a limit, no number; the forecaster's own chance of this, stated with the estimate: 75%; the middle value lies on the limit itself.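

Compound 1 and compound 3 both give only a limit of the assay, not a number, so no step between them can be read: the limit of > 63000 nM in this assay, at which 3 of the 3 values shown sit.

The compounds shown leave open how strongly any of them inhibits in this assay, and which group on the sulfonyl sulfur would give a measurable value.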